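Notes on a ring substituent change, compound 3 to compound 4

The compounds below may be only part of what the source reports. "The series", "measured", "known", "first", "only" and "open" are said of these compounds alone.

Values in a functional assay on A549 cells (Homo sapiens) for antiproliferative activity, read by MTT assay, with a stated time of 72 h; a higher number here means a weaker inhibitor, a lower number a stronger inhibitor:
- compound 1 `COc1cc2c(Nc3ccc(C#N)cc3)ncnc2cc1OCCCN(C)C` gives 60500 nM
- compound 2 `COc1cc2c(Nc3ccc(C#N)cc3)ncnc2cc1OCCCN1CCC(O)CC1` gives 29900 nM
- compound 3 `CCOC(=O)C1CCN(CCCOc2cc3ncnc(Nc4ccc(C#N)cc4)c3cc2OC)CC1` gives 89900 nM

Compound 3 sits level with compound 1, with a 1.5-fold higher number from compound 1 to compound 3 (0.17 log units; within the scatter), and clear of compound 2, with a 3.0-fold higher number from compound 2 to compound 3 (0.48 log units; beyond the scatter). Compound 4 `COc1cc2c(Nc3ccc(C#N)cc3)ncnc2cc1OCCCN1CCC(N(C)C)CC1` is still unmeasured. It differs by dimethylamino in place of ethoxycarbonyl on a saturated ring carbon. The closest evidence is a 3.0-fold higher number from compound 2 to compound 3 (0.48 log units; beyond the scatter), a change at this same ring carbon, and a 2.0-fold lower number from compound 1 to compound 2 (0.31 log units; beyond the scatter) is also modest. Neither tests dimethylamino on this ring, so only a small move toward lower numbers in this assay is expected. The expected change is a 1.8-fold lower number from compound 3 to compound 4 (0.25 log units; within the scatter). Compound 4 is estimated at 50000 nM, within 18000 nM to 110000 nM.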

Compound 4, half-maximal inhibitory concentration: 42400 nM
The estimate for compound 4 lay 1.2-fold (0.07 log units) above the measured number; measured number inside the range.
By their numbers in this assay, from the lowest: compounds 2, 4, 1 and 3 (each within the scatter of the next, the first and the last beyond it).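

In this assay, dimethylamino on this saturated ring carbon stands apart from ethoxycarbonyl (a 2.1-fold lower number from compound 3 to compound 4 (0.33 log units; beyond the scatter)) but stays level with hydroxy (a 1.4-fold higher number from compound 2 to compound 4 (0.15 log units; within the scatter)). On the chain, 4-(dimethylamino)piperidin-1-yl stays level with plain dimethylamino (a 1.4-fold lower number from compound 1 to compound 4 (0.15 log units; within the scatter)). Nothing available bears on the cause of these steps.

Still open, on these data alone, is how a primary amine or a carboxylic acid on this ring carbon would compare with dimethylamino, hydroxy and ethoxycarbonyl. Also open, as far as these compounds go, is whether a longer chain would alter these steps.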